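The compounds below may be only part of what the source reports. "The series", "measured", "known", "first", "only" and "open" are said of these compounds alone.

Of the compounds shown here, three have been measured so far in a functional assay on HepG2 cells (Homo sapiens) for inhibition, read by MTT assay, with a stated time of 72 h, tested at 50 uM; a lower number here means less inhibition of growth, a higher number more inhibition of growth at the concentration tested. Compound 1 (`C=CCc1cc(O)c(O)c(CN2CCC(CCO)CC2)c1`) gives 2%, compound 2 (`C=CCc1ccc(OCc2cn(-c3ccccc3Cl)nn2)c(O)c1`) gives 4.7%, and compound 3 (`C#CCOc1ccc(CC=C)cc1O`) gives 5.6%. The number for compound 2 lies within the usual scatter of the other two, so these results set no order among the three compounds. Compound 4 (`C=CCc1ccc(OCc2cn(-c3ccccc3CO)nn2)c(O)c1`) differs from compound 2 in one place: hydroxymethyl stands in place of chloro on an aromatic carbon, ortho to a large group (hydroxymethyl in place of chloro on an aromatic carbon). Among the measured compounds shown here, no measured pair of compounds shows what this swap does in this assay, so the data give no firm direction for it. The best starting point is compound 2 at 4.7%, and only a small change is expected. The expected step, a number 1.3 percentage points higher from compound 2 to compound 4 (within the scatter), stays within the scatter. In this assay, compound 4 is expected at 6%, with an estimated range from 0% to 18%.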

Compound 4, percent growth inhibition at one concentration: 8.5%
Compound 4: middle estimate off by 2.5 percentage points, on the low side; low and high end bracket the measured number.
By their numbers in this assay, from the lowest: compounds 1, 2, 3 and 4 (each within the scatter of the next).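

In this assay, the swap of chloro for hydroxymethyl on an aromatic carbon, ortho to a large group, now has a measured result, a number 3.8 percentage points higher from compound 2 to compound 4 (within the scatter), so the two compounds cannot be told apart. At this position, then, a group with 1 hydrogen-bond donor and 1 hydrogen-bond acceptor can stand where chloro, with neither, stood, and the result still does not leave the usual scatter of this measurement. Nothing available bears on what lies behind this result.

As far as these compounds go, whether any group at this position can move the number beyond the scatter remains open, and an amine such as aminomethyl or a carboxylic acid would be a natural test. A single step also says nothing about other positions on this ring or about other parts of the shared core.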